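This account rests on a few compounds, and the source may have more. Where it says the series, first, only, none or still open, it means among the compounds named here.

Measured compounds in an assay on isolated protein for binding affinity to 5-hydroxytryptamine receptor 6 (Homo sapiens); on this read-out lower numbers stand for stronger inhibition and higher numbers for weaker inhibition:

Compound 1 `COc1ccc(-c2n[nH]cc2N2CCCNCC2)cc1` gives > 10000 nM, which is a limit of the assay and not a number.
Compound 2 `c1ccc(-c2n[nH]cc2N2CCCNCC2)cc1` gives 3480 nM.
Compound 3 `COc1ccc(-c2n[nH]cc2N2CCNCC2)cc1` gives 279 nM.

Working notes. Within the core shared by compound 1 and compound 2, the one measured step is an at least 2.8-fold lower number from compound 1 to compound 2 (0.45 log units; beyond the scatter), the change being (hydrogen in place of methoxy on an aromatic carbon). The value of compound 1 rests on (the limit of > 10000 nM in this assay, at which 1 of the 3 values shown sits), so the size of this step is known only as a lower bound. Compound 3 carries a different core; how the two cores differ is not broken down here. What the values show is that compound 3 stands well below compound 2 in this assay, the gap being beyond the scatter.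

Compound 4 `c1ccc(-c2n[nH]cc2N2CCNCC2)cc1` differs from compound 3 by hydrogen in place of methoxy on an aromatic carbon. Among the measured compounds shown here, this is the same change as the one from compound 1 to compound 2, made on the other core. If it behaves as the earlier step did, a lower number is expected for compound 4, though the earlier step is only bounded and was observed on one core alone, so the transfer to the core of compound 3 is uncertain. The step from compound 3 to compound 4 in this assay is therefore estimated as a 1.9-fold lower number from compound 3 to compound 4 (0.27 log units; within the scatter), a modest gain, resting on compound 1 and compound 2 and on an at least 2.8-fold lower number from compound 1 to compound 2 (0.45 log units; beyond the scatter). For compound 4 the expected value in this assay is 150 nM, with a range of 40 nM to 600 nM.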

Compound 4, inhibition constant: 185 nM
The estimate for compound 4 lay 1.2-fold (0.09 log units) below the measured number; measured number inside the range.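

In this assay, hydrogen in place of methoxy on the core of compound 3 gives a 1.5-fold lower number from compound 3 to compound 4 (0.18 log units; within the scatter), so on this core the change has no effect that can be told apart from the scatter. This does not show that the change transfers with a constant size, nor that its size depends on the core, and two cores are too few to support a general rule for the series: the same change on two cores in this assay, an at least 2.8-fold lower number (0.45 log units; beyond the scatter) from compound 1 to compound 2 and a 1.5-fold lower number (0.18 log units; within the scatter) from compound 3 to compound 4; the limit leaves it open whether they differ The value of compound 1 is a limit and not a number, so the step on the first core has a bound but no known size: the limit of > 10000 nM in this assay, at which 1 of the 4 values shown sits.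

The compounds shown carry only hydrogen or methoxy at this place on the six-membered aromatic ring, so it remains open how fluorine, chlorine, a methyl group or a hydroxyl group there would read on either core. Also open, on these data alone, is how a methyl group or a longer chain on the free ring amine would read, and whether such a substituent would leave the comparison between the two cores unchanged.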